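Adding a Chlorine to a Weakly Cytotoxic Benzothiazole Ether

A few compounds are considered here, and "the series" means these few. Any claim that something is new, unique, unknown or untested is made for them only; others in the source may bear on it.

Of the compounds shown here, two sharing the same core have been tested for their ability to kill colon cancer cells. Compound 1 `Fc1ccc(-n2cc(COc3ccccc3-c3nc4ccccc4s3)nn2)cc1` carries a 4-fluorophenyl group on one end of the molecule, while compound 2 `COc1ccc(-c2cc(COc3ccccc3-c3nc4ccccc4s3)on2)cc1` carries a 4-methoxyphenyl group on a different five-membered ring. In a functional assay on COLO 205 cells (Homo sapiens) for cytotoxicity, read by MTT assay, with a stated time of 24 h (a higher number here means a weaker inhibitor, a lower number a stronger inhibitor), compound 1 gives 18900 nM. In this assay compound 2 gives 20700 nM. These two values are so close that the gap between them falls within the scatter that repeated measurements of this kind normally show, so neither compound can be called the stronger of the pair.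

The next compound to consider is compound 3 `Fc1ccc(-n2cc(COc3ccccc3-c3nc4ccccc4s3)nn2)cc1Cl`, which differs from compound 1 in a single place: chloro in place of hydrogen on an aromatic carbon. Within the data shown here, no pair of measured compounds shows what such a change does here, so there is no step to lean on. The expectation is that the step of a 1.2-fold lower number from compound 1 to compound 3 (0.07 log units; within the scatter) stays within the scatter, with no clear change in either direction. Compound 3 is therefore estimated to give 16000 nM in this assay, with a plausible range from 6000 nM to 40000 nM.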

Compound 3, half-maximal inhibitory concentration: 14400 nM
The estimate for compound 3 lay 1.1-fold (0.05 log units) above the measured number, and the stated range covers the measured number.
By their numbers in this assay, from the lowest: compounds 3, 1 and 2 (each within the scatter of the next).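

Going from 4-fluorophenyl to 3-chloro-4-fluorophenyl gives a direct reading of one change at a single place, on an aromatic carbon ortho to a fluoro group and meta to a large group. In this assay, the change gives a 1.3-fold lower number from compound 1 to compound 3 (0.12 log units; within the scatter) and so cannot be told apart from the normal spread of repeated measurements. What this pair adds is that a single chlorine at this position produces no clear change in the cell-killing number, so the position can carry this atom with no measurable effect in either direction, and no reason for that can be offered from the information available here.

The compounds shown leave open whether a group that differs more from hydrogen than chlorine does, such as an amine or a carboxylic acid, would move the number clearly at this same position. They also leave open whether chloro in place of hydrogen would give a similar result on the 4-methoxyphenyl group of compound 2, or on a phenyl ring with no fluoro group.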